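Piperazine nitrogen substituents and antiproliferative activity on A-375 cells

The source may hold more compounds than are shown below. What is called first, only, known or untested is meant among the compounds shown, and "the series" means these compounds.

Compound 1 `Nc1ccccc1NC(=O)c1ccc(CSC(=S)N2CCN(Cc3ccccn3)CC2)cc1`: in a functional assay on A-375 cells (Homo sapiens) for antiproliferative activity, read by CCK-8 assay, with a stated time of 72 h, tested at 2 uM (on this read-out higher numbers stand for a stronger effect at the one concentration tested and lower numbers for a weaker effect), compound 1 gives 20.7%
Compound 2 `CN1CCN(C(=S)SCc2ccc(C(=O)Nc3ccccc3N)cc2)CC1`: in this assay compound 2 gives 36.6%

Compound 2 stands highest of the two measured numbers, its nearest neighbour compound 1 being a number 15.9 percentage points higher from compound 1 to compound 2 (beyond the scatter). Compound 3 `Nc1ccccc1NC(=O)c1ccc(CSC(=S)N2CCN(c3ccncc3)CC2)cc1` differs from compound 2 by pyridin-4-yl in place of methyl on an amine nitrogen in a ring. The only measured step bears on it indirectly: removing a ring-bearing group from that nitrogen raised the number, as shown a number 15.9 percentage points higher from compound 1 to compound 2 (beyond the scatter), so placing a ring on the nitrogen again is expected to lower it modestly. Compound 3 is therefore estimated at 25%, between 10% and 45%, a step of a number 11.6 percentage points lower from compound 2 to compound 3 (beyond the scatter).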

Compound 3, a percentage reported as inhibition, at one concentration (the size of the read-out at that concentration, not a potency): 85.7%
Beside the measured number, compound 3's estimate is 60.7 percentage points below it; measured number above the stated range.
By their numbers in this assay, from the lowest: compound 1; then compound 2; then compound 3.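

Placing a ring on this amine nitrogen does not in itself lower the read-out in this assay: pyridin-4-yl in place of methyl gives a number 49.1 percentage points higher from compound 2 to compound 3 (beyond the scatter). Pyridin-4-yl in place of (pyridin-2-yl)methyl gives a number 65 percentage points higher from compound 1 to compound 3 (beyond the scatter), so the two ring-bearing groups stand at opposite ends of the three numbers, with methyl in the middle. Nothing available explains this gain.

The compounds shown leave open whether the direct attachment of the ring or the place of its nitrogen carries the step. A phenyl or a (pyridin-4-yl)methyl group on this nitrogen would separate the two.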